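A 2,6-dichlorobenzyl swap starting from a limit

The compounds below may be only part of what the source reports. "The series", "measured", "known", "first", "only" and "open" are said of these compounds alone.

In a functional assay on LNCaP cells (Homo sapiens) for cytotoxicity, read by MTT assay (on this read-out higher numbers stand for weaker inhibition and lower numbers for stronger inhibition), compound 1 `COc1ccc2cc([C@H](C)c3nnc(SCc4ccc(C)cc4)n3-c3ccc(F)cc3)ccc2c1` is reported only as a limit, <= 400000 nM. It therefore gives no exact starting point. Two close relatives do give numbers: compound 2 `COc1ccc2cc([C@H](C)c3nnc(SCc4ccccc4)n3-c3ccc(Cl)cc3)ccc2c1` shows 50400 nM, and compound 3 `COc1ccc2cc([C@H](C)c3nnc(SCc4ccc(C)cc4)n3-c3ccc(Cl)cc3)ccc2c1` shows 52200 nM.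

Compound 4 `COc1ccc2cc([C@H](C)c3nnc(SCc4c(Cl)cccc4Cl)n3-c3ccc(F)cc3)ccc2c1` keeps the core of compound 1 and changes one group: 2,6-dichlorophenyl in place of 4-methylphenyl on a saturated chain carbon bound to a sulfur. Cut one bond further out, this is 4-methylbenzyl to 2,6-dichlorobenzyl, on a saturated chain carbon bound to a sulfur.

Among the compounds with values here, two measured steps bear on this change. Chloro in place of fluoro on an aromatic carbon gives a step that the limit leaves unreadable from compound 1 to compound 3, so it sets no size. Methyl in place of hydrogen on an aromatic carbon gives a 1.0-fold higher number from compound 2 to compound 3 (0.02 log units; within the scatter), and this is the only readable step on the group being replaced. Within the data shown here, no compound measured so far carries chlorine on that group, so the guide is weak.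

With compound 3 at 52200 nM as the nearest anchor, no clear effect of the swap itself is expected. Set against the limit alone, the expected result is a step that the limit leaves unreadable from compound 1 to compound 4, a rough estimate. The estimate for compound 4 is 55000 nM, with an expected range of 12000 nM to 250000 nM.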

Compound 4, half-maximal inhibitory concentration: 12300 nM
Beside the measured number, compound 4's estimate is 4.5-fold (0.65 log units) above it; the range from low to high includes it.
By their numbers in this assay, from the lowest: compound 4; then compounds 2 and 3 (each within the scatter of the next).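

In this assay, the step from compound 1 to compound 4 cannot be read, because the value of compound 1 is a limit and not a number: the limit of <= 400000 nM in this assay, at which 1 of the 4 values shown sits. The compounds shown leave open what the change from 4-methylbenzyl to 2,6-dichlorobenzyl does by itself; no compound with an exact value differs from compound 4 in one place only.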